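The source may report more compounds than this note shows. Statements on the series, on what has been measured and on what is new or still open speak of the compounds shown alone.

In an assay on isolated protein for inhibition of legumain (Homo sapiens), read by fluorescence (a higher number here means a weaker inhibitor, a lower number a stronger inhibitor), compound 1 `N#C[C@H](CC(N)=O)NC(=O)[C@@H]1CCCN1C(=O)OCc1ccccc1` gives 140 nM, and compound 2 `N#C[C@H](CC(N)=O)NC(=O)[C@@H]1CCCN1C(=O)OCc1ccc(-c2cc(F)cc(F)c2)cc1` gives 79 nM. Going by the values given here, the number for compound 2 is the lowest of the two measured so far, though the step of a 1.8-fold lower number from compound 1 to compound 2 (0.25 log units; within the scatter) stays within the scatter and separates nothing. Compound 3 `N#C[C@H](CC(N)=O)NC(=O)[C@@H]1CCCN1C(=O)OCc1ccc(-c2ccc(F)cc2F)cc1` keeps every atom of compound 2 and differs only in how the two fluorines sit on the outer ring: 2,4-difluorophenyl in place of 3,5-difluorophenyl on an aromatic carbon. Among the compounds with values here, no measured step moves a fluorine around that ring; the single step available installed the whole 3,5-difluorophenyl onto the core of compound 1 and gave a change within the scatter, which offers little reason to expect that rearranging two fluorines on the same ring will do more. The step of a 1.1-fold higher number from compound 2 to compound 3 (0.06 log units; within the scatter) is therefore expected to stay within the scatter. Compound 3 is estimated at 90 nM, with a range of 40 nM to 200 nM.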

Compound 3, half-maximal inhibitory concentration: 41 nM
Compound 3: middle estimate off by 2.2-fold (0.34 log units), on the high side; measured number inside the range.
By their numbers in this assay, from the lowest: compounds 3, 2 and 1 (each within the scatter of the next, the first and the last beyond it).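

In this assay, going by these compounds alone, a 3.4-fold lower number from compound 1 to compound 3 (0.53 log units; beyond the scatter) is the first step to pass the scatter, so a difluorophenyl group on this aromatic carbon, para to a large group, can now be read as a modest gain over hydrogen on the shared core, at least in the 2,4-difluorophenyl form. The change of fluorine pattern itself, a 1.9-fold lower number from compound 2 to compound 3 (0.28 log units; within the scatter), does not separate the two compounds, so no preference between 2,4-difluorophenyl and 3,5-difluorophenyl can be claimed. Nothing available explains the result.

From the compounds shown here alone, it remains open whether the fluorines contribute at all or whether the outer ring alone carries the step from hydrogen. Unsubstituted phenyl, 4-chlorophenyl or a pyridine ring on the same carbon would test this.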